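Removing the Fluorophenyl Cap from a Thiosemicarbazone

The source may report more compounds than this note shows. Statements on the series, on what has been measured and on what is new or still open speak of the compounds shown alone.

Three thiosemicarbazones have been tested so far in a functional assay on HL-60 cells (Homo sapiens) for antiproliferative activity, read by sulforhodamine B assay, with a stated time of 72 h; a higher number here means a weaker inhibitor, a lower number a stronger inhibitor. Compound 1 `CN(C)C(=S)N/N=C/c1ccc2cccnc2n1` gives 560 nM. Compound 2 `Fc1ccccc1NC(=S)N/N=C/c1ccc2ccccc2n1` returns only a limit of the assay, > 100000 nM, not a number. Compound 3 `NC(=S)N/N=C/c1cc2ccccc2s1` likewise sits at a limit, > 100000 nM. Compound 2 thus stands at the limit of > 100000 nM in this assay, at which 2 of the 3 values shown sit, with no measurable potency shown.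

Compound 4 `NC(=S)N/N=C/c1ccc2ccccc2n1` differs from compound 2 by hydrogen in place of 2-fluorophenyl on an amide-type nitrogen. Among the compounds with values here, no measured pair shows this change, so the size of the step is unknown. Since compound 2 gives only a limit, a move to measurable potency is expected for compound 4, and the step from compound 2 to compound 4 is estimated at an at least 33-fold lower number from compound 2 to compound 4 (1.52 log units; beyond the scatter). Compound 4 is expected to give about 3000 nM, within 500 nM to 30000 nM.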

Compound 4, half-maximal inhibitory concentration: > 100000 nM
Compound 4: only a limit was reported; the forecaster's own chance of this, stated with the estimate: 15%; middle value at least 33-fold (1.52 log units) from the limit.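

Compound 2 and compound 4 both give only a limit of the assay, not a number, and the step between them cannot be read. The compounds shown leave open whether hydrogen in place of 2-fluorophenyl changes potency at all.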